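Extending the chain on the aromatic nitrogen of a shared core

This account rests on a few compounds, and the source may have more. Where it says the series, first, only, none or still open, it means among the compounds named here.

The three measured compounds, all read in an assay on CHO cells for displacement of a labelled ligand from adenosine receptor A1 (Homo sapiens), read by scintillation counting, with a stated time of 3 h; on this read-out lower numbers stand for stronger inhibition and higher numbers for weaker inhibition:

Compound 1, `CCn1c(-c2ccccc2)nc2c(NC3CCCCC3)ncnc21`, gives 10 nM.
Compound 2, `Cn1c(-c2ccccc2)nc2c(NC3CCCCC3)ncnc21`, gives 5.7 nM.
Compound 3, `CCn1c(-c2ccccc2)nc2c(N)ncnc21`, gives 31 nM.

Compound 2 and compound 1 differ in one place: methyl in place of hydrogen on a saturated chain carbon bound to an aromatic nitrogen. This gives a 1.8-fold higher number from compound 2 to compound 1 (0.24 log units; within the scatter), so the two numbers are not told apart. Compound 1 and compound 3 differ in one place as well, a hydrogen in place of cyclohexyl on a nitrogen on an aromatic ring, and here a 3.1-fold higher number from compound 1 to compound 3 (0.49 log units; beyond the scatter). Compound 3 thus has the highest number of the three. The difference between the cores of compound 2 and compound 3 is not broken down here.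

The unmeasured compound 4, `CCCn1c(-c2ccccc2)nc2c(N)ncnc21`, relates to compound 3 by methyl in place of hydrogen on a saturated chain carbon, two bonds along the chain from an aromatic nitrogen. This is the same kind of change as from compound 2 to compound 1, not the same: there the entering methyl sits on a saturated chain carbon bound to an aromatic nitrogen, whereas in compound 4 it sits on a saturated chain carbon two bonds along the chain from an aromatic nitrogen. Among the measured compounds shown here, only one earlier example of this kind of change is in hand, and it lies within the scatter. The expected step is a 1.3-fold higher number from compound 3 to compound 4 (0.11 log units; within the scatter), resting on the earlier step of a 1.8-fold higher number from compound 2 to compound 1 (0.24 log units; within the scatter), which stayed within the scatter. For compound 4 the estimated value in this assay is 40 nM, expected to fall between 18 nM and 90 nM.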

Compound 4, inhibition constant: 101 nM
For compound 4 the middle estimate is 2.5-fold (0.40 log units) below the measured one; the measured number lies above the stated range.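

In this assay, methyl in place of hydrogen on a saturated chain carbon, two bonds along the chain from an aromatic nitrogen, gives a 3.3-fold higher number from compound 3 to compound 4 (0.51 log units; beyond the scatter), and this step can be set beside the earlier one: the same change on two cores in this assay, a 1.8-fold higher number (0.24 log units; within the scatter) from compound 2 to compound 1 and a 3.3-fold higher number (0.51 log units; beyond the scatter) from compound 3 to compound 4, 1.9-fold (0.27 log units) apart, within the scatter of two such steps. The two steps are therefore not told apart, and the readings fit a change that carries from one core to the other with a similar size, even though only the newer step on its own lies beyond the scatter. Among the compounds shown here, this does not establish transfer across the series, since it rests on only two pairs, which differ in two ways: the methyl enters at a different place on the chain, turning methyl to ethyl in one pair and ethyl to propyl in the other, and the cores carry cyclohexyl or hydrogen on the nitrogen on the aromatic ring.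

The compounds shown leave open whether a propyl chain on the core of compound 1 would follow the same course, and whether a longer chain such as butyl or a branched chain such as isopropyl would continue it. They also leave open how the step would read with a cyclopentyl group in place of cyclohexyl on that nitrogen.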